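A few compounds are considered here, and "the series" means these few. Any claim that something is new, unique, unknown or untested is made for them only; others in the source may bear on it.

Measured so far in a functional assay for inhibition, with Homo sapiens as the target; a higher number here means a weaker inhibitor, a lower number a stronger inhibitor:
- Compound 1 `CC(C)(C)Sc1c(CC(C)(C)C(=O)O)n(Cc2ccc(Cl)cc2)c2ccc(OCc3ccc4cc(F)c(F)cc4n3)cc12`: 7 nM
- Compound 2 `CC(C)(C)Sc1c(CC(C)(C)C(=O)O)n(Cc2ccc(Cl)cc2)c2ccc(OCc3cc4ccccc4cn3)cc12`: 3 nM
- Compound 3 `CC(C)(C)Sc1c(CC(C)(C)C(=O)O)n(Cc2ccc(Cl)cc2)c2ccc(OCc3ccc4cnccc4n3)cc12`: 3 nM

Compound 3 gives 3 nM, level with compound 2, and these two share the lowest number of the three. Compound 4 `COc1ccc2nc(COc3ccc4c(c3)c(SC(C)(C)C)c(CC(C)(C)C(=O)O)n4Cc3ccc(Cl)cc3)sc2c1` has not been measured. It differs from compound 3 in one place: a group of 11 heavy atoms (8 carbon, 1 nitrogen, 1 oxygen, 1 sulfur; one five-membered aromatic ring with 2 hetero atoms, one six-membered aromatic ring of carbon only) in place of a group of 10 heavy atoms (8 carbon, 2 nitrogen; 2 six-membered aromatic rings with 1 hetero atom each), on a saturated chain carbon bound to an oxygen on an aromatic ring. The entering group is 6-methoxy-1,3-benzothiazol-2-yl.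

The three measured compounds differ from one another in this same place, so their steps are the closest guide. They are a 2.3-fold lower number from compound 1 to compound 2 (0.37 log units; beyond the scatter), a 2.3-fold lower number from compound 1 to compound 3 (0.37 log units; beyond the scatter) and no change at the digits printed from compound 2 to compound 3 (within the scatter). The first two are modest. Among the compounds with values here, no measured compound carries a five-membered aromatic ring here, so none shows this change directly.

Compound 1 at 7 nM holds the largest group of the three, and the group entering compound 4 is also larger than the one it replaces. A modest move toward a higher number is therefore expected in this assay, not a large one. The estimated change is a 1.7-fold higher number from compound 3 to compound 4 (0.22 log units; within the scatter). For compound 4 the expected value is 5 nM, with an estimated range of 2 nM to 14 nM.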

Compound 4, half-maximal inhibitory concentration: 8 nM
Compound 4: middle estimate off by 1.6-fold (0.20 log units), on the low side; measured number inside the range.
By their numbers in this assay, from the lowest: compounds 2 and 3 (each within the scatter of the next); then compounds 1 and 4 (each within the scatter of the next).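

In this assay, 6-methoxy-1,3-benzothiazol-2-yl brings the first five-membered aromatic ring to this position, giving a 2.7-fold higher number from compound 3 to compound 4 (0.43 log units; beyond the scatter) and a 2.7-fold higher number from compound 2 to compound 4 (0.43 log units; beyond the scatter), so this change of ring type costs only a modest amount. The comparison with the larger group of compound 1 shows a 1.1-fold higher number from compound 1 to compound 4 (0.06 log units; within the scatter), which means that among these four compounds the two larger groups, in compounds 1 and 4, both lie beyond the scatter from compounds 2 and 3. Nothing measured here bears on the reason for these differences.

The compounds shown cannot separate the part played by the methoxy group from that of the ring system, which 1,3-benzothiazol-2-yl without the methoxy group would address. Also open, as far as these compounds go, is how a single ring, such as pyridin-2-yl, would behave at this place.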